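Cyclobutyl amide to 2-chlorophenyl amide on a shared core

The source may hold more compounds than are shown below. What is called first, only, known or untested is meant among the compounds shown, and "the series" means these compounds.

Three amides of the shared core have been measured in an assay on LtK cells with ATP-sensitive inward rectifier potassium channel 11 (Homo sapiens) as the target; on this read-out higher numbers stand for an effect only at larger amounts of compound and lower numbers for an effect already at smaller amounts. Compound 1 `CC(C)C(=O)Nc1c(C(O)(C(F)(F)F)C(F)(F)F)ccc2ccccc12` gives 6630 nM; compound 2 `CCCC(=O)Nc1c(C(O)(C(F)(F)F)C(F)(F)F)ccc2ccccc12` gives 131 nM; compound 3 `O=C(Nc1c(C(O)(C(F)(F)F)C(F)(F)F)ccc2ccccc12)C1CCC1` gives 45 nM. Compound 3 stands lowest of the three, with a 2.9-fold lower number from compound 2 to compound 3 (0.46 log units; beyond the scatter) and a 150-fold lower number from compound 1 to compound 3 (2.17 log units; beyond the scatter). The step of a 51-fold lower number from compound 1 to compound 2 (1.70 log units; beyond the scatter) shows how strongly the group on the carbonyl carbon can move the number.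

Compound 4 `O=C(Nc1c(C(O)(C(F)(F)F)C(F)(F)F)ccc2ccccc12)c1ccccc1Cl` differs from compound 3 in one place: 2-chlorophenyl in place of cyclobutyl on a carbonyl carbon. Among the measured compounds shown here, none of the measured steps swaps a saturated group for an aromatic one, so they bear on the change only by showing that this position is sensitive. The large steps from compound 1 and the modest step from compound 2 suggest the change need not be small, yet its direction cannot be read from them. The estimate for compound 4 in this assay is therefore a step of a 3.3-fold higher number from compound 3 to compound 4 (0.52 log units; beyond the scatter), expected to be towards higher numbers but with a wide range: compound 4 is expected to give 150 nM, between 20 nM and 1500 nM.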

Compound 4, half-maximal effective concentration: 2040 nM
Beside the measured number, compound 4's estimate is 14-fold (1.13 log units) below it, and the stated range ends below it.
By their numbers in this assay, from the lowest: compound 3; then compound 2; then compound 4; then compound 1.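

In this assay, among the compounds shown here, this is the first swap of a saturated group for an aromatic one on this carbonyl carbon, and it gives a 45-fold higher number from compound 3 to compound 4 (1.66 log units; beyond the scatter). The 2-chlorophenyl amide also falls short of the straight-chain amide, with a 16-fold higher number from compound 2 to compound 4 (1.19 log units; beyond the scatter), but it does not give the highest number of the set, as a 3.3-fold lower number from compound 1 to compound 4 (0.51 log units; beyond the scatter) shows. From the lowest number, the groups at this position therefore run cyclobutyl, propyl, 2-chlorophenyl, isopropyl, so the aromatic group lies within the range already set by the saturated groups.

The compounds shown leave open whether the rise belongs to the phenyl ring or to its chlorine, a question that a plain phenyl amide would address, while a cyclopentyl amide would test how far the low numbers extend among saturated rings. No measurement at hand accounts for these steps.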